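Amino added on the benzyl ring of compound 1

The source may report more compounds than this note shows. Statements on the series, on what has been measured and on what is new or still open speak of the compounds shown alone.

Two compounds of the series have numbers in a functional assay on HCT-116 cells (Homo sapiens) for antiproliferative activity, read by MTT assay, with a stated time of 48 h; a lower number here means a stronger inhibitor, a higher number a weaker inhibitor. Compound 1 `COc1ccc(CN(C(=O)CSc2nc3ccccc3s2)c2cc(OC)c(OC)c(OC)c2)cc1` gives 426 nM in this assay. Compound 2 `COc1ccc2nc(SCC(=O)N(Cc3ccc(OC)c(O)c3)c3cc(OC)c(OC)c(OC)c3)sc2c1` gives 352 nM in this assay. Compound 1 holds the higher of the two numbers, yet its gap to compound 2 lies within the scatter, so the two are not told apart on what has been measured. For the measured compounds named here, no pair of measured compounds differs in one place only, so no single step size is established; compound 2 differs from compound 1 at more than one place and is read only as a second number near that of compound 1.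

Compound 3 `COc1ccc(CN(C(=O)CSc2nc3ccccc3s2)c2cc(OC)c(OC)c(OC)c2)cc1N` has not been measured. It differs from compound 1 by amino in place of hydrogen on an aromatic carbon. Going by the values given here, nothing measured speaks for a large step in either direction, and the one neighbour with a substituent added on the same ring sits within the scatter of compound 1. The expected step from compound 1 to compound 3 is therefore small, a 1.1-fold lower number from compound 1 to compound 3 (0.03 log units; within the scatter), none beyond the scatter. For compound 3 the estimate in this assay is 400 nM, with a range from 150 nM to 1100 nM.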

Compound 3, half-maximal inhibitory concentration: 491 nM
Compound 3: the middle estimate sits 1.2-fold (0.09 log units) below what was measured; low and high end bracket the measured number.
By their numbers in this assay, from the lowest: compounds 2, 1 and 3 (each within the scatter of the next).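

In this assay, for the compounds shown here, amino in place of hydrogen gives a 1.2-fold higher number from compound 1 to compound 3 (0.06 log units; within the scatter), the first step that isolates a single place. The aromatic carbon ortho to a methoxy group, on the change from 4-methoxybenzyl to 3-amino-4-methoxybenzyl, therefore takes an amino group with no shift that can be told from the scatter, so this one substitution leaves the number of the core of compound 1 where it was. No measurement on hand offers an explanation for this result or shows what the amino group does at this place.

From the compounds shown here alone, one substitution cannot show whether the place is insensitive in general, and whether a dimethylamino group, an acetylamino group, a nitro group or a chlorine on the same carbon would produce a step beyond the scatter remains open. Also open, going by these compounds, is whether the amino group gives a similar result when it stands on another carbon of the same ring, or when the same change is made on a different core.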